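Methylsulfanyl to aminoamino on the shared core: compound 4

The source may report more compounds than this note shows. Statements on the series, on what has been measured and on what is new or still open speak of the compounds shown alone.

Three compounds have numbers in a functional assay, with a stated time of 150 min (a higher number here means a weaker inhibitor, a lower number a stronger inhibitor), so far. Compound 1 `CCOC(=O)c1cnn(-c2nc(-c3ccccc3Cl)c(C#N)c(=O)n2C)c1N` gives 93 ug/mL in this assay, and compound 2 `CCOC(=O)c1cnn(-c2nc(-c3ccc(OC)cc3)c(C#N)c(=O)n2C)c1N` gives 79 ug/mL. Among the measured compounds shown here, the one measured step, a 1.2-fold lower number from compound 1 to compound 2 (0.07 log units; within the scatter), changes a group at a place other than the one now in question. Compound 3 `COc1cccc(-c2nc(SC)n(C)c(=O)c2C#N)c1OC` gives 67 ug/mL in this assay; it sits at the low end of the three numbers, but its gaps to compound 2 and to compound 1 both lie within the scatter, so the three are not separated by the measurements.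

Compound 4 `COc1cccc(-c2nc(NN)n(C)c(=O)c2C#N)c1OC` is not yet measured. It differs from compound 3 by aminoamino in place of methylsulfanyl on an aromatic carbon. For the measured compounds named here, no measured step touches this position or this pair of groups, and the step from compound 1 to compound 2 at another position stayed within the scatter, so nothing in the data points in either direction. The working expectation is therefore a step of no change at the digits printed from compound 3 to compound 4 (within the scatter), none beyond the scatter. Compound 4 is expected to give about 67 ug/mL in this assay, with a range from 30 ug/mL to 150 ug/mL.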

Compound 4, half-maximal inhibitory concentration: 54 ug/mL
Estimate against measurement, compound 4: 1.2-fold (0.09 log units) above; measured number inside the range.
By their numbers in this assay, from the lowest: compounds 4, 3, 2 and 1 (each within the scatter of the next).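

Among the compounds shown here, this is the first measured step at this position, the aromatic carbon between two ring nitrogen atoms and para to a cyano group. In this assay aminoamino in place of methylsulfanyl gives a 1.2-fold lower number from compound 3 to compound 4 (0.09 log units; within the scatter) and so does not separate the two compounds. The exchange keeps the count of 2 heavy atoms but goes from 0 to 2 hydrogen-bond donors, and the measurements show no effect of it beyond the scatter; no data at hand bear on the reason for this result.

On these data alone, whether a different group at this position, such as a simple amine, a carboxylic acid or a longer chain, would give a step beyond the scatter remains open. Also open, as far as these compounds go, is whether this exchange reads the same with another aryl group on the shared core, such as 4-methoxyphenyl.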